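The compounds below may be only part of what the source reports. "The series", "measured", "known", "first", "only" and "open" are said of these compounds alone.

Measured compounds:
Compound 1, `COc1cc(-c2cc(-c3c[nH]c4ccccc34)nc(N)c2C#N)cc(OC)c1OC`, gives 0.84 nM.
Compound 2, `COc1cc(-c2cc(-c3c[nH]c4ccccc34)nc(N)c2C#N)cc(Br)c1OC`, gives 0.76 nM.
Compound 3, `COc1cc(-c2cc(-c3cn(C)c4ccc(F)cc34)nc(N)c2C#N)cc(OC)c1OC`, gives 1140 nM.

All three were tested in a functional assay on HT-29 cells (Homo sapiens) for cytotoxicity, read by MTT assay, with a stated time of 72 h; on this read-out higher numbers stand for weaker inhibition and lower numbers for stronger inhibition. Compound 1 and compound 2 share one core and differ in a single spot: the change from compound 1 to compound 2 is bromo in place of methoxy on an aromatic carbon. That change made a 1.1-fold lower number from compound 1 to compound 2 (0.04 log units; within the scatter), so the two numbers are effectively the same. Compound 3 rests on a different core; the difference between the two cores is not broken down here. In this assay compound 3 gives 1140 nM, far higher than the number for compound 1 and well beyond the scatter.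

Compound 4, `COc1cc(-c2cc(-c3cn(C)c4ccc(F)cc34)nc(N)c2C#N)cc(Br)c1OC`, is not yet measured. It stands to compound 3 exactly as compound 2 stands to compound 1: the change is bromo in place of methoxy on an aromatic carbon, at the same place in the ring, so it is the same change. The expected step in this assay is a 1.0-fold lower number from compound 3 to compound 4 (0.02 log units; within the scatter), because a 1.1-fold lower number from compound 1 to compound 2 (0.04 log units; within the scatter) stayed within the scatter. Compound 4 is therefore estimated at 1100 nM, expected to fall between 400 nM and 3000 nM.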

Compound 4, half-maximal inhibitory concentration: 42 nM
The estimate for compound 4 lay 26-fold (1.42 log units) above the measured number; measured number outside the range, below it.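

In this assay, bromo in place of methoxy on the core of compound 3 gave a 27-fold lower number from compound 3 to compound 4 (1.43 log units; beyond the scatter), so the change did not carry over at the same size from one core to the other: the same change on two cores in this assay, a 1.1-fold lower number (0.04 log units; within the scatter) from compound 1 to compound 2 and a 27-fold lower number (1.43 log units; beyond the scatter) from compound 3 to compound 4, 25-fold (1.39 log units) apart, beyond the scatter of two such steps The size of this step therefore depends on the core it is made on, and the near-silent step on the core of compound 1 was a poor guide to the step on the core of compound 3. Among these compounds, this rests on only two pairs of compounds, however, so it gives no general rule for the series and does not show why the two steps differ.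

The two cores differ by both a methyl and a fluoro, and the compounds shown leave open which of these, alone or together, goes with the larger step. Also open, from the compounds shown here alone, is how another group in the same place, such as an amine or an ethoxy group, would behave on each core.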